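Pyridin-4-yl for pyridin-3-yl: expected cytotoxicity of compound 4

The source may report more compounds than this note shows. Statements on the series, on what has been measured and on what is new or still open speak of the compounds shown alone.

Series notes. Compound 1 `COc1cc(/C=C2\CN(C)C/C(=C\c3cccnc3)C2=O)cc(OC)c1OC` and compound 2 `CN1C/C(=C\c2cccnc2)C(=O)/C(=C/c2ccccc2F)C1` are built on different cores; the difference between the two cores is not broken down here. In a functional assay on QGY-7703 cells (Homo sapiens) for cytotoxicity, read by MTT assay, with a stated time of 24 h (on this read-out higher numbers stand for weaker inhibition and lower numbers for stronger inhibition), compound 1 gives 4300 nM and compound 2 gives 4470 nM; the two values lie within the usual scatter of each other. Compound 3 `COc1cc(/C=C2\CN(C)C/C(=C\c3ccncc3)C2=O)cc(OC)c1OC` carries pyridin-4-yl in place of pyridin-3-yl on a double-bonded chain carbon bound to a double-bonded ring carbon relative to compound 1, and in this assay compound 3 gives 5900 nM. For the measured compounds named here, the step of a 1.4-fold higher number from compound 1 to compound 3 (0.14 log units; within the scatter) is the only measured instance of this change.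

Compound 4 `CN1C/C(=C\c2ccncc2)C(=O)/C(=C/c2ccccc2F)C1`, not yet measured, carries pyridin-4-yl in place of pyridin-3-yl on a double-bonded chain carbon bound to a double-bonded ring carbon on the core of compound 2. The place of the change is the same as in the pair of compound 1 and compound 3, so the change is taken as the same. The expectation for compound 4 rests on that single step: the step from compound 2 to compound 4 in this assay is estimated as a 1.3-fold higher number from compound 2 to compound 4 (0.11 log units; within the scatter), which follows from a 1.4-fold higher number from compound 1 to compound 3 (0.14 log units; within the scatter). Going by the values given here, on that basis compound 4 is expected to give about 5800 nM in this assay, with a range of 3000 nM to 11000 nM, the width reflecting that only one prior instance of the change exists.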

Compound 4, half-maximal inhibitory concentration: 4900 nM
Estimate against measurement, compound 4: 1.2-fold (0.07 log units) above, and the stated range covers the measured number.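

In this assay, the new reading of pyridin-4-yl in place of pyridin-3-yl is a 1.1-fold higher number from compound 2 to compound 4 (0.04 log units; within the scatter). Set beside the earlier step, it does not differ: the same change on two cores in this assay, a 1.4-fold higher number (0.14 log units; within the scatter) from compound 1 to compound 3 and a 1.1-fold higher number (0.04 log units; within the scatter) from compound 2 to compound 4, 1.3-fold (0.10 log units) apart, within the scatter of two such steps. Within this series, the change therefore carries from one core to the other without a step beyond the scatter, but two small steps on two cores show only that agreement and do not establish that the change is neutral on any further core.

The compounds shown leave open what a plain phenyl, a pyridin-2-yl, or a pyridine ring bearing an amine or a carboxylic acid would give on a double-bonded chain carbon bound to a double-bonded ring carbon, and only such a group could show whether this place tolerates more than the exchange of pyridin-3-yl and pyridin-4-yl. From the compounds shown here alone, whether the two steps would also agree in other cell lines or over other exposure times remains open as well.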